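The source may report more compounds than this note shows. Statements on the series, on what has been measured and on what is new or still open speak of the compounds shown alone.

Measured so far in a functional assay on CAKI-1 cells (Homo sapiens) for antiproliferative activity; a higher number here means a weaker inhibitor of growth, a lower number a stronger inhibitor of growth:
- compound 1 `Oc1cc(-c2ccc3ccccc3c2)nc2ncccc12` gives 5620 nM
- compound 2 `Cc1ccnc2nc(-c3ccc4ccccc4c3)cc(O)c12` gives 2400 nM
- compound 3 `Cc1ccc2c(O)cc(-c3ccc4ccccc4c3)nc2n1` gives 5370 nM

Compound 3 sits with compound 1 at the upper end of these numbers (a 1.0-fold lower number from compound 1 to compound 3 (0.02 log units; within the scatter)), and the value of compound 2 lies lower. Compound 4 `Cc1cc(C)c2c(O)cc(-c3ccc4ccccc4c3)nc2n1` differs from compound 3 by methyl in place of hydrogen on an aromatic carbon on an aromatic carbon opposite the ring nitrogen. Compound 2 carries its methyl at that same place, so its step (a 2.3-fold lower number from compound 1 to compound 2 (0.37 log units; beyond the scatter)) is the closest guide, and the methyl of compound 3 shows only that a second site can leave the number unmoved. A modest step to a lower number is therefore expected (a 2.1-fold lower number from compound 3 to compound 4 (0.32 log units; beyond the scatter)). Compound 4 is estimated at 2600 nM within an expected range from 1200 nM to 5400 nM in this read-out.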

Compound 4, concentration for 50% growth inhibition: 51300 nM
For compound 4 the middle estimate is 20-fold (1.30 log units) below the measured one, and the stated range ends below it.
By their numbers in this assay, from the lowest: compound 2; then compounds 3 and 1 (each within the scatter of the next); then compound 4.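

Methyl in place of hydrogen on the aromatic carbon opposite the ring nitrogen gives a 9.6-fold higher number from compound 3 to compound 4 (0.98 log units; beyond the scatter) in this assay, so at this position the same change moves the number in opposite directions on the two cores: the same change on two cores in this assay, a 2.3-fold lower number (0.37 log units; beyond the scatter) from compound 1 to compound 2 and a 9.6-fold higher number (0.98 log units; beyond the scatter) from compound 3 to compound 4, 22-fold (1.35 log units) apart, beyond the scatter of two such steps

The other methyl also depends on its partner, giving a 21-fold higher number from compound 2 to compound 4 (1.33 log units; beyond the scatter) where it left the number unmoved on the core of compound 1: the same change on two cores in this assay, a 1.0-fold lower number (0.02 log units; within the scatter) from compound 1 to compound 3 and a 21-fold higher number (1.33 log units; beyond the scatter) from compound 2 to compound 4, 22-fold (1.35 log units) apart, beyond the scatter of two such steps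

The two methyl groups therefore do not add. The compounds shown leave open why this is so, and whether an ethyl, a methoxy or an amine at this position would follow methyl.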